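Difluorophenyl for methylphenyl on the shared core

This account rests on a few compounds, and the source may have more. Where it says the series, first, only, none or still open, it means among the compounds named here.

The series shares the core of compound 1 `Cc1ccc(-c2cnn3c(NCc4ccccn4)cc(C)nc23)cc1`. In a physicochemical assay for solubility, read by HPLC, using the shake flask method, measured as kinetic solubility, with a stated time of 2 h, at pH 7.4 (a higher number here means a more soluble compound, a lower number a less soluble compound), compound 1 gives only a limit, < 5000 nM, not a number. Compound 2 `Cc1cc(NCc2cnccn2)n2nc(C)c(-c3ccccc3)c2n1` gives 7100 nM in this assay. Compound 3 `Cc1cccc(CNc2cc(C)nc3c(-c4ccccc4)c(C)nn23)n1` returns a limit of < 5000 nM in this assay. Going by the values given here, the one measured step, an at least 1.4-fold lower number from compound 2 to compound 3 (0.15 log units; that floor lies within the scatter), changes a group at a different place on the core; the limit of < 5000 nM in this assay, at which 2 of the 3 values shown sit, marks where two of the three values stand. Compound 4 `Cc1cc(NCc2ccccn2)n2ncc(-c3ccc(F)cc3F)c2n1` carries 2,4-difluorophenyl in place of 4-methylphenyl on an aromatic carbon. Among the compounds with values here, no measured step touches this aromatic carbon, so no change beyond the scatter is expected, and the limit may well recur. Compound 4 is therefore expected at 3000 nM, within 1000 nM to 8000 nM. The step that the limit leaves unreadable from compound 1 to compound 4 so expected lies within the scatter.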

Compound 4, solubility: < 5000 nM
Compound 4: a limit, no number; the forecaster's own chance of this, stated with the estimate: 70%; the middle value lies beyond the limit too.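

The step from compound 1 to compound 4 cannot be read in this assay: both values are limits, not numbers. The compounds shown leave open what 2,4-difluorophenyl in place of 4-methylphenyl on an aromatic carbon does to the number in this assay.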